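The source may report more compounds than this note shows. Statements on the series, on what has been measured and on what is new or still open speak of the compounds shown alone.

Values in a functional assay on A549 cells (Homo sapiens) for antiproliferative activity, read by MTT assay, with a stated time of 72 h; a higher number here means a weaker inhibitor, a lower number a stronger inhibitor:
compound 1 `O=C(N/N=C/c1ccc([N+](=O)[O-])cc1)Nc1ccc(Oc2ccnc3[nH]ccc23)c(F)c1`: 20 nM
compound 2 `O=C(N/N=C/c1ccc(Cl)c(Cl)c1)Nc1ccc(Oc2ccnc3[nH]ccc23)c(F)c1`: 2650 nM
compound 3 `O=C(N/N=C/c1ccc([N+](=O)[O-])cc1)Nc1ccc(Oc2ccnc3[nH]ccc23)cc1`: 2100 nM
compound 4 `CN(C)CCn1cccc1/C=N/NC(=O)Nc1ccc(Oc2ccnc3[nH]ccc23)c(F)c1`: not yet measured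

Compound 2 at 2650 nM lies within the scatter of compound 3 and far from compound 1. The next change gives compound 4 (1-(2-(dimethylamino)ethyl)-1H-pyrrol-2-yl in place of 3,4-dichlorophenyl on a carbon with a double bond to nitrogen): 1-(2-(dimethylamino)ethyl)-1H-pyrrol-2-yl in place of 3,4-dichlorophenyl on a carbon with a double bond to nitrogen. The large step of a 130-fold higher number from compound 1 to compound 2 (2.12 log units; beyond the scatter) occurred at this same place and bears most directly. The large step of a 110-fold higher number from compound 1 to compound 3 (2.02 log units; beyond the scatter) occurred elsewhere and shows only that this assay can shift widely within the series. Among the measured compounds shown here, no measured compound carries the entering group, so a moderate move to a lower number is expected. The expected step is a 4.4-fold lower number from compound 2 to compound 4 (0.65 log units; beyond the scatter) and remains uncertain. For compound 4 the estimate is 600 nM with an expected range of 80 nM to 3500 nM here.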

Compound 4, half-maximal inhibitory concentration: "not active" (no number reported)
Compound 4: no number reported; the estimate stays without a comparison.
By their numbers in this assay, from the lowest: compound 1; then compounds 3 and 2 (each within the scatter of the next).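

Among the compounds shown here, compound 4 is reported as not active in this assay with no number; no step from compound 2 to compound 4 can be read. No available evidence bears on this result. The compounds shown leave open how far compound 4 lies from compound 2.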